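Swapping the carbamoyl of compound 2 for a methyl-oxazolyl ring

The source may hold more compounds than are shown below. What is called first, only, known or untested is meant among the compounds shown, and "the series" means these compounds.

Of the compounds shown here, three sharing one core have been measured in an assay on membranes from CHO cells for displacement of a labelled ligand from adenosine receptor A1 (Homo sapiens), read by scintillation counting, with a stated time of 60 min, tested at 1 uM; on this read-out higher numbers stand for more inhibition at the one concentration tested (going by the name of the read-out) and lower numbers for less inhibition. Compound 1 `CC(=O)C1=C(C)NC(=O)NC1c1ccoc1` gives 6%, compound 2 `CC1=C(C(N)=O)C(c2ccoc2)NC(=O)N1` gives 1%, and compound 3 `CCN(CC)C(=O)C1=C(C)NC(=O)NC1c1ccoc1` gives 15%. Compound 2 stands lowest of the three: a number 5 percentage points lower from compound 1 to compound 2 (within the scatter), while a number 14 percentage points higher from compound 2 to compound 3 (beyond the scatter). The third step, a number 9 percentage points higher from compound 1 to compound 3 (within the scatter), also stays within the scatter.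

Compound 4 `CC1=C(c2ncc(C)o2)C(c2ccoc2)NC(=O)N1` has not yet been measured in this assay . It differs from compound 2 in one place: 5-methyl-1,3-oxazol-2-yl in place of carbamoyl on a double-bonded ring carbon. Going by the values given here, every measured step changes only the substituent on the carbonyl carbon of the carbamoyl group, whereas this step replaces the carbamoyl group as a whole on the double-bonded ring carbon, so no measured step addresses it directly. The closest analogy is compound 2 to compound 3, where replacing the amino with diethylamino gave a modest gain, but a gain from a different exchange cannot be carried over with confidence. The step is therefore expected to be small, most likely none beyond the scatter, with a number 9 percentage points higher from compound 2 to compound 4 (within the scatter) as the expected shift. Compound 4 is estimated at 10% in this assay , with an expected range from 0% to 25%.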

Compound 4, a percentage reported as inhibition, at one concentration (the size of the read-out at that concentration, not a potency): 21%
The estimate for compound 4 lay 11 percentage points below the measured number; the range from low to high includes it.
By their numbers in this assay, from the lowest: compounds 2, 1, 3 and 4 (each within the scatter of the next, the first and the last beyond it).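

In this assay, going by these compounds alone, the earlier compounds varied only what sits on the carbonyl carbon, whereas here the whole carbamoyl gives way to 5-methyl-1,3-oxazol-2-yl on the double-bonded ring carbon, and the position accepts this aromatic ring with no carbonyl attached to the core, with a number that rises beyond the scatter (a number 20 percentage points higher from compound 2 to compound 4 (beyond the scatter)). Set against the acetyl, the same ring also clears the scatter (a number 15 percentage points higher from compound 1 to compound 4 (beyond the scatter)), so the rise is not tied to carbamoyl as the only reference, while compound 3 at 15% and compound 4 at 21% stay within the scatter of each other, which leaves the ring and the diethylamino carbonyl unseparated on this read-out. Nothing available explains why the ring gives this result.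

The compounds shown leave open whether the ring alone carries the rise or its methyl contributes, as an oxazol-2-yl without the methyl, or a thiazole or a phenyl at the same carbon, would show. They also leave open whether a carboxylic acid or a nitrile would be accepted at this position, and what any of these compounds does at other concentrations.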